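The source may report more compounds than this note shows. Statements on the series, on what has been measured and on what is new or still open speak of the compounds shown alone.

Measured compounds:
- compound 1 `Cc1nc(-c2ccc(C(F)(F)F)cc2)sc1CNc1ccc(CC(=O)O)cc1` — in a functional assay on CHO cells for agonist activity at Free fatty acid receptor 1 (Homo sapiens) (a higher number here means that more compound is needed for the effect, a lower number that less compound is needed), compound 1 gives < 10000 nM, which is a limit of the assay rather than a number.
- compound 2 `CC(C)NC(=O)CCc1ccc(NCc2cccc(Oc3ccccc3)c2)cc1` — compound 2 gives 39.8 nM.
- compound 3 `CN(C)C(=O)CCc1ccc(NCc2cccc(Oc3ccccc3)c2)cc1` — compound 3 gives 174 nM.

Compound 1 therefore stands only at a limit: its value in this assay is known to lie on one side of the assay's reach, and no more can be read from it (the limit of < 10000 nM in this assay, at which 1 of the 3 values shown sits). Among the measured compounds shown here, compounds 2 and 3 share a core different from that of compound 1 and carry amide tails instead of an acid; the one measured step between them, a 4.4-fold higher number from compound 2 to compound 3 (0.64 log units; beyond the scatter), concerns only the exchange of one amine on the carbonyl carbon for another.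

Compound 4 `Cc1nc(-c2ccc(C(F)(F)F)cc2)sc1CNc1ccc([C@H]2C[C@@H]2C(=O)NO)cc1` keeps the core of compound 1 and differs from it in one place: 2-(hydroxycarbamoyl)cyclopropyl in place of carboxymethyl on an aromatic carbon. For the measured compounds named here, no measured step touches this kind of exchange, so the step from compound 2 to compound 3 gives no direct guide, and the limit for compound 1 leaves the starting point itself open. The expectation for compound 4 is thus a value somewhere inside the range that compound 1's limit allows, without a firm direction, and the step expected is a step that the limit leaves unreadable from compound 1 to compound 4. For compound 4 the estimate is 800 nM, with a range from 100 nM to 6000 nM.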

Compound 4, half-maximal effective concentration: 6.92 nM
Beside the measured number, compound 4's estimate is 120-fold (2.06 log units) above it; measured number below the stated range.
By their numbers in this assay, from the lowest: compound 4; then compound 2; then compound 3.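

No step can be read from compound 1 to compound 4, because the value of compound 1 is a limit of the assay and not a number: the limit of < 10000 nM in this assay, at which 1 of the 4 values shown sits.

The compounds shown leave open whether any difference between these two compounds belongs to the cyclopropyl ring, to the hydroxycarbamoyl group, or to both, since the two enter together in 2-(hydroxycarbamoyl)cyclopropyl.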